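Hydroxy in place of bromo: expected cytotoxicity

This account rests on a few compounds, and the source may have more. Where it says the series, first, only, none or still open, it means among the compounds named here.

Among the measured compounds shown here, compound 2 `Cn1nnnc1SCC(=O)N/N=C/c1cccc(Br)c1` gives 600000 nM in a functional assay on A549 cells (Homo sapiens) for cytotoxicity, read by XTT assay, with a stated time of 24 h (on this read-out lower numbers stand for stronger inhibition and higher numbers for weaker inhibition), the lowest of the two numbers so far. Compound 1 `Cn1nnnc1SCC(=O)N/N=C/c1cccc(F)c1` gives 6320000 nM. For the measured compounds named here, the single measured step, an 11-fold lower number from compound 1 to compound 2 (1.02 log units; beyond the scatter), is large. Compound 3 `Cn1nnnc1SCC(=O)N/N=C/c1cccc(O)c1` differs from compound 2 by hydroxy in place of bromo on an aromatic carbon. Going by the values given here, no measured step pairs a halogen with a hydroxy group, so the bromo step is only indirect guidance; it shows that a change at this position can move the number strongly. Compound 3 is therefore expected to show a rise beyond the scatter, a 5.0-fold higher number from compound 2 to compound 3 (0.70 log units; beyond the scatter). The estimate for compound 3 is 3000000 nM, with a range from 600000 nM to 15000000 nM.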

Compound 3, half-maximal inhibitory concentration: 4500000 nM
Compound 3: the middle estimate sits 1.5-fold (0.18 log units) below what was measured; the range from low to high includes it.
By their numbers in this assay, from the lowest: compound 2; then compounds 3 and 1 (each within the scatter of the next).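

Hydroxy in place of bromo gives a 7.5-fold higher number from compound 2 to compound 3 (0.88 log units; beyond the scatter) on this read-out, and hydroxy in place of fluoro gives a 1.4-fold lower number from compound 1 to compound 3 (0.15 log units; within the scatter) by comparison. Among the three groups at this position, only bromo stands apart, while hydroxy and fluoro are not separated by their numbers. No evidence at hand explains the bromo result. From the compounds shown here alone, it remains open whether chloro or iodo would give a number close to that of bromo. Going by these compounds, it is also open whether an amine or a methoxy group would instead fall with hydroxy and fluoro.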